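A few compounds are considered here, and "the series" means these few. Any claim that something is new, unique, unknown or untested is made for them only; others in the source may bear on it.

Measured compounds in an assay on CHO cells, read by calcium flux; on this read-out higher numbers stand for weaker inhibition and lower numbers for stronger inhibition:
compound 1 `O=C(Nc1ccccc1)c1csc(Cc2c(Cl)cccc2Cl)n1` gives > 4000 nM
compound 2 `O=C(Nc1ccc(C(F)(F)F)cc1)c1csc(Cc2c(Cl)cccc2Cl)n1` gives 88 nM
compound 3 `O=C(Nc1ccc(C(F)(F)F)nc1)c1csc(Cc2c(Cl)cccc2Cl)n1` gives 130 nM
compound 4 `O=C(Nc1cccc(Br)c1)c1csc(Cc2c(Cl)cccc2Cl)n1` is not yet measured

Compound 1 stands at the weak end of this assay: its value is a limit of the assay and not a number, as noted in the limit of > 4000 nM in this assay, at which 1 of the 3 values shown sits. Among the measured compounds shown here, the only measured step from it is an at least 45-fold lower number from compound 1 to compound 2 (1.65 log units; beyond the scatter), where the trifluoromethyl group makes the anilide far more potent. Compound 3 carries the same trifluoromethyl group on a different ring and gives 130 nM, close to compound 2.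

Compound 4 differs from compound 1 by bromo in place of hydrogen on an aromatic carbon, so the bromo enters a phenyl that otherwise carries no substituent. For the measured compounds named here, since the single substituent change measured here moved the number a long way, a step in the same direction is expected for compound 4, though a halogen placed meta to a large group is not the change that was measured, so the estimate is cautious. Compound 4 is estimated at 700 nM, within 150 nM to 4000 nM. The expected step is an at least 5.7-fold lower number from compound 1 to compound 4 (0.75 log units; beyond the scatter).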

Compound 4, half-maximal inhibitory concentration: > 4000 nM
Compound 4 was reported as a limit (the forecaster's own chance of this, stated with the estimate: 25%); middle value at least 5.7-fold (0.75 log units) away from the limit.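

Among the compounds shown here, compound 1 and compound 4 both stand at a limit of the assay and not at a number, so no step between them can be read: the limit of > 4000 nM in this assay, at which 2 of the 4 values shown sit. The compounds shown leave open whether 3-bromophenyl in place of phenyl changes the inhibition at all.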